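A few compounds are considered here, and "the series" means these few. Any claim that something is new, unique, unknown or untested is made for them only; others in the source may bear on it.

Measured so far in a toxicity assay on cells (Macrophage, Mus musculus, strain BALB/c) for cytotoxicity, read by MTT assay; a lower number here means a stronger inhibitor, a higher number a weaker inhibitor: compound 1 `COc1cc(O)cc(O)c1C(=O)/C=C/c1ccc(C(F)(F)F)cc1` gives 17100 nM; compound 2 `COc1cc(O)cc(O)c1C(=O)/C=C/c1ccc(Cl)cc1` gives 19000 nM; compound 3 `C=CCOc1cc(OC)c(C(=O)/C=C/c2ccc([N+](=O)[O-])cc2)c(OCC=C)c1` gives 13200 nM.

Compound 2 stands among these three without any separation beyond the scatter: compound 1 lies within it, and so does compound 3. The step to compound 4 `COc1cc(O)cc(O)c1C(=O)/C=C/c1ccc(F)cc1` is fluoro in place of chloro on an aromatic carbon. Within the data shown here, one measured step bears on it, the exchange of one small group for another at the same place on the ring, a 1.1-fold higher number from compound 1 to compound 2 (0.05 log units; within the scatter), which stayed within the scatter. On that basis no step beyond the scatter is expected in this assay from compound 2 to compound 4, in either direction. Compound 4 is therefore expected to give about 19000 nM, within a range from 9000 nM to 40000 nM, an estimated step of no change at the digits printed from compound 2 to compound 4 (within the scatter).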

Compound 4, half-maximal inhibitory concentration: 28800 nM
The estimate for compound 4 lay 1.5-fold (0.18 log units) below the measured number, within the range that was stated.
By their numbers in this assay, from the lowest: compounds 3, 1, 2 and 4 (each within the scatter of the next, the first and the last beyond it).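

In this assay, fluoro, chloro and trifluoromethyl can now be compared at the same place on the ring, para to a large group, with a 1.5-fold higher number from compound 2 to compound 4 (0.18 log units; within the scatter) and a 1.7-fold higher number from compound 1 to compound 4 (0.23 log units; within the scatter). Both steps stay within the scatter, so these three groups cannot be told apart at this place in this assay. No measurement available here explains these numbers.

On these data alone, whether an amine, a carboxylic acid or a longer chain at this place would give a step beyond the scatter remains open.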